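Five-membered heteroaryl replaces 4-methylpyridin-3-yl: compound 4

The compounds below may be only part of what the source reports. "The series", "measured", "known", "first", "only" and "open" are said of these compounds alone.

Among the measured compounds shown here, compound 3 `Cc1ccncc1-c1ncnc2c1cnn2CCN1CCCCC1` stands highest of the three numbers so far in an assay on HEK293 cells for displacement of a labelled ligand from Sigma non-opioid intracellular receptor 1 (Homo sapiens), read by scintillation counting, with a stated time of 120 min (on this read-out higher numbers stand for weaker inhibition and lower numbers for stronger inhibition), giving 707 nM. Compound 1 `Cc1cccc(-c2ncnc3c2cnn3CCN2CCCCC2)c1` gives 82 nM and compound 2 `Fc1ccc(-c2ncnc3c2cnn3CCN2CCCCC2)cc1` gives 95 nM; a 1.2-fold higher number from compound 1 to compound 2 (0.06 log units; within the scatter) stays within the scatter, while an 8.6-fold higher number from compound 1 to compound 3 (0.94 log units; beyond the scatter) and a 7.4-fold higher number from compound 2 to compound 3 (0.87 log units; beyond the scatter) lie beyond it. Compound 4 `c1coc(-c2ncnc3c2cnn3CCN2CCCCC2)n1` has not been measured. It differs from compound 3 in one place: 1,3-oxazol-2-yl in place of 4-methylpyridin-3-yl on an aromatic carbon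

For the measured compounds named here, no measured step exchanges one heteroaryl for another, so the only guidance comes from an 8.6-fold higher number from compound 1 to compound 3 (0.94 log units; beyond the scatter) and a 7.4-fold higher number from compound 2 to compound 3 (0.87 log units; beyond the scatter), where the ring with a ring nitrogen gave the higher number than either phenyl. Nothing measured has a five-membered ring at this position, so the direction is uncertain, but a number at or beyond that of compound 3 seems more likely than a return toward compound 1. For compound 4 the expected value in this assay is estimated at 900 nM, with a range from 250 nM to 3500 nM. The expected step is a 1.3-fold higher number from compound 3 to compound 4 (0.10 log units; within the scatter).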

Compound 4, inhibition constant: 23800 nM
Compound 4: the middle estimate sits 26-fold (1.42 log units) below what was measured, outside the stated range (above it).
By their numbers in this assay, from the lowest: compounds 1 and 2 (each within the scatter of the next); then compound 3; then compound 4.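

In this assay, the 1,3-oxazol-2-yl group on this aromatic carbon gives a far higher number than any of the six-membered aromatic rings: a 34-fold higher number from compound 3 to compound 4 (1.53 log units; beyond the scatter), a 250-fold higher number from compound 2 to compound 4 (2.40 log units; beyond the scatter) and a 290-fold higher number from compound 1 to compound 4 (2.46 log units; beyond the scatter). Among the compounds shown here, all three steps exceed the largest among the earlier compounds, an 8.6-fold higher number from compound 1 to compound 3 (0.94 log units; beyond the scatter), so this position separates these rings much more sharply than the earlier compounds showed, although ring size, hetero atom count and the loss of ring substituents all change together in this exchange. No measurement available here bears on the reason for this jump.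

Which of those changes carries the effect remains open. A thiophen-2-yl ring, a 4-methyl-1,3-oxazol-2-yl group or an unsubstituted pyridin-3-yl ring at this position would help to separate them.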